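The source may report more compounds than this note shows. Statements on the series, on what has been measured and on what is new or still open speak of the compounds shown alone.

Working notes on the series in a functional assay on HCT-116 cells (Homo sapiens) for cytotoxicity, read by sulforhodamine B assay, with a stated time of 48 h; a lower number here means a stronger inhibitor, a higher number a weaker inhibitor. Compound 1 `COc1ccc(C(=O)Nc2n[nH]c3c2CN(C(=O)c2ccccc2)C3)cc1` gives 13600 nM, compound 3 `CCCCNC(=O)N1Cc2c(NC(=O)c3ccccc3)nn(C(=O)c3ccccc3)c2C1` gives 7470 nM, and compound 2 `CCCCNC(=O)N1Cc2c(NC(=O)c3ccccc3)nn(C(=O)C3CC3)c2C1` gives 3470 nM. That last number is the lowest of the three, and both other numbers lie beyond the scatter from it.

Compound 4 `CCCCNC(=O)N1Cc2c(NC(=O)c3ccc(C)cc3)nn(C(=O)C3CC3)c2C1` keeps compound 2 intact except for one change, benzamido to ((4-methylphenyl)carbonyl)amino: methyl in place of hydrogen on an aromatic carbon. This is methyl in place of hydrogen on an aromatic carbon, para to a large group.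

Going by the values given here, only one measured step connects compounds: a 2.2-fold higher number from compound 2 to compound 3 (0.33 log units; beyond the scatter). It is modest, and it replaces cyclopropyl with phenyl on a carbonyl carbon, so it does not touch the ring that changes here. Among the compounds with values here, no measured compound carries a substituent on that ring, which leaves the direction of the new step open. That single step gives only a rough idea of how far a change can move this series. A step within the scatter is therefore expected in this assay, with no favoured direction.

The expected change is a 1.0-fold higher number from compound 2 to compound 4 (0.00 log units; within the scatter). For compound 4 the estimated value is 3500 nM, with an expected range of 1700 nM to 7200 nM.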

Compound 4, half-maximal inhibitory concentration: 17600 nM
Estimate against measurement, compound 4: 5.0-fold (0.70 log units) below; measured number outside the range, above it.
By their numbers in this assay, from the lowest: compound 2; then compounds 3, 1 and 4 (each within the scatter of the next, the first and the last beyond it).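

In this assay the ring of the benzamido group now has a measured response: a 5.1-fold higher number from compound 2 to compound 4 (0.71 log units; beyond the scatter), with methyl in place of hydrogen on an aromatic carbon, para to a large group. Going by these compounds alone, a single added heavy atom at this place therefore moves the number beyond the scatter and toward a weaker inhibitor, a direction that the earlier compounds, none with a substituent on this ring, could not show; the only earlier step, a 2.2-fold higher number from compound 2 to compound 3 (0.33 log units; beyond the scatter), lies at a carbonyl carbon elsewhere in the molecule and also goes upward. No available measurement bears on what lies behind this rise.

Going by these compounds, whether the rise belongs to methyl alone or to any substituent at this place stays open, and fluorine, chlorine, methoxy or a carboxylic acid on the same carbon would separate those readings. Also open, on these data alone, is whether methyl on this ring gives a similar step when phenyl replaces cyclopropyl on the carbonyl carbon, as in compound 3, since the present step stands on the cyclopropyl compounds only.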